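The compounds below may be only part of what the source reports. "The series", "measured", "known", "first", "only" and "open" are said of these compounds alone.

Series notes, single-concentration read-out. In a functional assay on CHO cells with adenosine receptor A1 (Homo sapiens) as the target, read by cAMP accumulation and immunoassay, with a stated time of 6 min, tested at 10 uM (a lower number here means a stronger effect, a higher number a weaker effect of the compound at the concentration tested), compound 1 `Nc1scc(CN2CCN(c3ccc(Cl)cc3Cl)CC2)c1C(=O)c1ccc(Cl)cc1` gives -74%. Compound 2 `Nc1scc(CN2CCN(c3ccc(F)cc3F)CC2)c1C(=O)c1ccc(Cl)cc1` gives -82% in this assay, and compound 3 `Nc1scc(CN2CCN(c3cccc(F)c3F)CC2)c1C(=O)c1ccc(Cl)cc1` gives -79% in this assay. The three numbers sit close together. Compound 3 holds the second highest of the three values, and both of its neighbours lie within the scatter of it: a number 3 percentage points higher from compound 2 to compound 3 (within the scatter), and a number 5 percentage points lower from compound 1 to compound 3 (within the scatter). The remaining measured step, a number 8 percentage points lower from compound 1 to compound 2 (within the scatter), is likewise within the scatter.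

Next in the series is compound 4 `Nc1scc(CN2CCN(c3ccc(F)c(Cl)c3)CC2)c1C(=O)c1ccc(Cl)cc1`. The change from compound 3 is 3-chloro-4-fluorophenyl in place of 2,3-difluorophenyl on an amine nitrogen in a ring. All three measured steps concern the same place, the aryl ring on the amine nitrogen in the ring, and each exchanged halogen pattern there without a step beyond the scatter. The expectation for this assay is therefore the same: no step beyond the scatter, a number 1 percentage points higher from compound 3 to compound 4 (within the scatter). Compound 4 is accordingly estimated at -78% in this assay, with a range from -90% to -66%.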

Compound 4, a percentage reported as activity, at one concentration (the size of the read-out at that concentration, not a potency): -78%
Compound 4: the middle estimate sits on the measured number at the digits printed; low and high end bracket the measured number.
By their numbers in this assay, from the lowest: compounds 2, 3, 4 and 1 (each within the scatter of the next).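

3-chloro-4-fluorophenyl is the first group in this series to carry two different halogens on the aryl ring on the amine nitrogen, and in this assay it does not separate from any of the earlier groups (a number 1 percentage points higher from compound 3 to compound 4 (within the scatter)) (a number 4 percentage points higher from compound 2 to compound 4 (within the scatter)) (a number 4 percentage points lower from compound 1 to compound 4 (within the scatter)). This place therefore accepts a mixed halogen pattern as well as the 2,4-dichlorophenyl, 2,4-difluorophenyl and 2,3-difluorophenyl patterns, with no read-out dividing the four groups. Nothing available explains this sameness.

Only halogens stand on this ring in the compounds shown, so it remains open whether a methoxy, a nitrile, a trifluoromethyl or an unsubstituted phenyl would hold the read-out. Also open, from the compounds shown here alone, is whether these four compounds differ in potency, as a single concentration gives no potency.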